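The source may hold more compounds than are shown below. What is called first, only, known or untested is meant among the compounds shown, and "the series" means these compounds.

Three compounds share one core and were read in a functional assay on MOLT-4 cells (Homo sapiens) for inhibition, read by sulforhodamine B assay, with a stated time of 48 h; on this read-out lower numbers stand for stronger inhibition of growth and higher numbers for weaker inhibition of growth. Compound 1 `COc1cc(C)cc(-c2c(-c3ccnc(-c4ccc(C(C)=O)cc4)c3)cnn2CC#N)c1` gives 2630 nM. Compound 2 `Cc1cc(O)cc(-c2nn(CC#N)cc2-c2ccnc(-c3ccc(Oc4ccccc4)cc3)c2)c1` gives 2030 nM. Compound 3 `COc1cc(C)cc(-c2nn(CC#N)cc2-c2ccnc(-c3ccc(N(C)C)cc3)c2)c1` gives 626 nM, the lowest of the three, beyond the scatter from both compound 2 and compound 1. Compound 4 `Cc1cc(O)cc(-c2nn(CC#N)cc2-c2ccnc(-c3ccc(N(C)C)cc3)c2)c1` has not been measured; it differs from compound 3 by hydrogen in place of methyl on an oxygen on an aromatic ring. Going by the values given here, no measured pair isolates this change, and compound 2 carries the hydroxy with a different partner group, so no direct guide exists. A small step is expected, if any, from compound 3 to compound 4 in this assay, not clearly beyond the scatter, and slightly weaker: a 1.4-fold higher number from compound 3 to compound 4 (0.16 log units; within the scatter). Compound 4 is therefore estimated at 900 nM, between 300 nM and 2700 nM.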

Compound 4, concentration for 50% growth inhibition: 3170 nM
Estimate against measurement, compound 4: 3.5-fold (0.55 log units) below; measured number outside the range, above it.
By their numbers in this assay, from the lowest: compound 3; then compounds 2, 1 and 4 (each within the scatter of the next).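

In this assay, going by these compounds alone, hydrogen in place of methyl on the oxygen gives a 5.1-fold higher number from compound 3 to compound 4 (0.70 log units; beyond the scatter), the first direct reading of this position, and it shows that the change from methoxy to hydroxy is beyond the scatter. With the hydroxy held, dimethylamino in place of phenoxy gives a 1.6-fold higher number from compound 2 to compound 4 (0.19 log units; within the scatter), which is within the scatter, so these two groups are not told apart in that setting. Nothing available explains the step from methoxy to hydroxy. The compounds shown leave open how an ethoxy group or an amine would read on this aromatic ring.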